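This account rests on a few compounds, and the source may have more. Where it says the series, first, only, none or still open, it means among the compounds named here.

Three compounds that share one core and differ only in the ring on a carbonyl carbon have been measured in a functional assay on PC-3 cells (Homo sapiens) for inhibition, read by colorimetric assay and sulforhodamine B assay, with a stated time of 48 h; a lower number here means a stronger inhibitor of growth, a higher number a weaker inhibitor of growth. Compound 1 `CCCCCCCCCCCC[C@@H](O)[C@H]1CC[C@H]([C@H](O)CCCCCCCCCCNC(=O)c2ccoc2)O1`, with furan-3-yl, gives 52500 nM. Compound 2 `CCCCCCCCCCCC[C@@H](O)[C@H]1CC[C@H]([C@H](O)CCCCCCCCCCNC(=O)c2cncs2)O1`, with 1,3-thiazol-5-yl, gives 100000 nM. Compound 3 `CCCCCCCCCCCC[C@@H](O)[C@H]1CC[C@H]([C@H](O)CCCCCCCCCCNC(=O)c2ccsc2)O1`, with thiophen-3-yl, gives 1700 nM, the lowest of the three numbers.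

Compound 4 `CCCCCCCCCCCC[C@@H](O)[C@H]1CC[C@H]([C@H](O)CCCCCCCCCCNC(=O)c2ccnn2C)O1` has 1-methyl-1H-pyrazol-5-yl in place of thiophen-3-yl on a carbonyl carbon. This ring has not been measured in the series, so the closest guide is the other ring swaps. Two steps end at thiophen-3-yl, a 31-fold lower number from compound 1 to compound 3 (1.49 log units; beyond the scatter) and a 59-fold lower number from compound 2 to compound 3 (1.77 log units; beyond the scatter), and both are large. The two rings without thiophen-3-yl stay within the scatter of each other, a 1.9-fold higher number from compound 1 to compound 2 (0.28 log units; within the scatter). Compound 3 therefore looks like the exception, and a large step to a higher number is expected, estimated as a 24-fold higher number from compound 3 to compound 4 (1.37 log units; beyond the scatter). The estimated value for compound 4 is 40000 nM, with an expected range from 8000 nM to 120000 nM.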

Compound 4, concentration for 50% growth inhibition: 18200 nM
Estimate against measurement, compound 4: 2.2-fold (0.34 log units) above; the range from low to high includes it.
By their numbers in this assay, from the lowest: compound 3; then compound 4; then compounds 1 and 2 (each within the scatter of the next).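

In this assay, the new ring leaves thiophen-3-yl in front, with an 11-fold higher number from compound 3 to compound 4 (1.03 log units; beyond the scatter), so the advantage of compound 3 now holds against three other rings on the carbonyl carbon. Compound 4 also shows that the rings other than thiophen-3-yl do not all behave alike. It separates from both earlier compounds, with a 5.5-fold lower number from compound 2 to compound 4 (0.74 log units; beyond the scatter) and a 2.9-fold lower number from compound 1 to compound 4 (0.46 log units; beyond the scatter). The position therefore gives a graded response: compound 4 sits in the middle, while compounds 1 and 2 remain within the scatter of each other.

A plain phenyl ring, or thiophen-2-yl with the same ring atoms joined to the carbonyl at a different point, would test how closely the result depends on the exact thiophen-3-yl ring. Nothing given here accounts for these differences between the rings.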